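Sulfamoyl in Place of Methylsulfonyl on the Compound 1 Core

The compounds below may be only part of what the source reports. "The series", "measured", "known", "first", "only" and "open" are said of these compounds alone.

Measured so far:
compound 1 `CS(=O)(=O)c1ccc(Nc2nccc(Nc3nc4ccc(F)cc4s3)n2)cc1` gives 560 nM
compound 2 `CS(=O)(=O)c1ccc(Nc2ncc(F)c(Nc3nc4ccc(F)cc4s3)n2)cc1` gives > 50000 nM
compound 3 `CS(=O)(=O)c1ccc(Nc2nccc(Nc3nc4ccc(Cl)cc4s3)n2)cc1` gives 1400 nM

The read-out throughout is a functional assay on HeLa cells (Homo sapiens) for antiproliferative activity, read by MTT assay, with a stated time of 48 h; a higher number here means a weaker inhibitor, a lower number a stronger inhibitor. Compound 1 gives the lowest of the two numbers shown, with compound 3 nearest; the step of a 2.5-fold higher number from compound 1 to compound 3 (0.40 log units; beyond the scatter) is modest. For compound 2 the value is a limit of the assay (the limit of > 50000 nM in this assay, at which 1 of the 3 values shown sits), and the step of an at least 89-fold higher number from compound 1 to compound 2 (1.95 log units; beyond the scatter) is large. Both measured steps alter the ring system of the core, not the sulfonyl.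

Compound 4 `NS(=O)(=O)c1ccc(Nc2nccc(Nc3nc4ccc(F)cc4s3)n2)cc1` differs from compound 1 at the sulfonyl sulfur: amino in place of methyl on a sulfonyl sulfur. Among the compounds with values here, no measured step touches this part of the core, so neither an at least 89-fold higher number from compound 1 to compound 2 (1.95 log units; beyond the scatter) nor a 2.5-fold higher number from compound 1 to compound 3 (0.40 log units; beyond the scatter) bears directly on it; they only show that the series tolerates some change modestly and other change not at all. With nothing closer to rest on, the change is expected to stay near compound 1, i.e. a step of a 1.3-fold higher number from compound 1 to compound 4 (0.10 log units; within the scatter) that may well fall within the scatter. Compound 4 is therefore estimated at 700 nM, with a range from 200 nM to 2500 nM.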

Compound 4, half-maximal inhibitory concentration: 450 nM
Beside the measured number, compound 4's estimate is 1.6-fold (0.19 log units) above it; measured number inside the range.
By their numbers in this assay, from the lowest: compounds 4 and 1 (each within the scatter of the next); then compound 3. At a limit, above all of these: compound 2.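

In this assay, amino in place of methyl on the sulfonyl sulfur gives a 1.2-fold lower number from compound 1 to compound 4 (0.09 log units; within the scatter), so this change cannot be told apart from the scatter. Within the data shown here, this is the first reading at the sulfonyl rather than in the ring system of the core, and it shows that the methyl is not needed to keep activity in this range: sulfamoyl, which adds a hydrogen-bond donor, serves as well as methylsulfonyl on this core. The data at hand give no measured basis for explaining why the two groups read alike.

Still open, as far as these compounds go, is how the sulfur position responds to other groups, such as dimethylamino or ethyl on the sulfur, or a carboxylic acid in place of the whole methylsulfonyl. Also open, from the compounds shown here alone, is whether sulfamoyl reads the same on the core of compound 3.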